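A few compounds are considered here, and "the series" means these few. Any claim that something is new, unique, unknown or untested is made for them only; others in the source may bear on it.

Compounds measured in a functional assay on HeLa cells (Homo sapiens) for inhibition; a lower number here means a stronger inhibitor, a higher number a weaker inhibitor:
- compound 1 `Oc1cccc(-c2cc(-c3cccc(F)c3)cc(-c3ccccc3O)n2)c1`: > 50000 nM (a limit, not a number)
- compound 2 `Oc1ccc(-c2cc(-c3cccc(F)c3)cc(-c3ccccc3O)n2)cc1`: > 50000 nM (likewise a limit)
- compound 3 `Oc1cccc(-c2cc(-c3ccccc3C(F)(F)F)cc(-c3ccccc3O)n2)c1`: 16800 nM

Compound 1 sits at the assay limit, as shown by the limit of > 50000 nM in this assay, at which 2 of the 3 values shown sit. Among the measured compounds shown here, the step that the two limits leave unreadable from compound 1 to compound 2 is therefore unreadable, while an at least 2.9-fold lower number from compound 1 to compound 3 (0.47 log units; beyond the scatter) is the only readable step and stays weak. Compound 4 `Oc1cccc(-c2cc(-c3cccc(OC(F)(F)F)c3)cc(-c3ccccc3O)n2)c1` differs from compound 1 by trifluoromethoxy in place of fluoro on an aromatic carbon. The move to another fluorinated group on the same ring in compound 3 gave the step of an at least 2.9-fold lower number from compound 1 to compound 3 (0.47 log units; beyond the scatter), so a comparable or smaller shift is expected, with a fair chance the result stays a limit. The expected step of an at least 1.6-fold lower number from compound 1 to compound 4 (0.22 log units; that floor lies within the scatter) gives, for compound 4, an estimate of 30000 nM in this assay, ranging from 8000 nM to 60000 nM.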

Compound 4, half-maximal inhibitory concentration: 14900 nM
Beside the measured number, compound 4's estimate is 2.0-fold (0.30 log units) above it; measured number inside the range.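

At the place of the fluoro, meta to a large group, trifluoromethoxy brings a measurable value in this assay, with an at least 3.3-fold lower number from compound 1 to compound 4 (0.52 log units; beyond the scatter). This shows that a readable change is possible at this ring place itself, with a group of more heavy atoms than fluoro. The true size of the step stays unknown because compound 1 carries only a limit: the limit of > 50000 nM in this assay, at which 2 of the 4 values shown sit.

From the compounds shown here alone, whether the oxygen or the fluorines of trifluoromethoxy carry the step stays open, and methoxy at this place would separate them. Going by these compounds, how an amine or a carboxylic acid would read here is also open.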